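The source may report more compounds than this note shows. Statements on the series, on what has been measured and on what is new or still open speak of the compounds shown alone.

a functional assay on DU-145 cells (Homo sapiens) for cytotoxicity, read by trypan blue exclusion, with a stated time of 96 h (on this read-out higher numbers stand for weaker inhibition and lower numbers for stronger inhibition), has two measured compounds so far. For the measured compounds named here, compound 1 (`COc1ccc(NS(=O)(=O)/C=C/c2c(OC)cc(OC)cc2OC)cc1`) gives 200 nM, and compound 2 (`COc1cc(OC)c(/C=C/S(=O)(=O)Nc2ccc(OC)c(F)c2)c(OC)c1`) gives 200 nM, so compound 2 stands level with its only neighbour. Compound 3 (`COc1cc(OC)c(/C=C/S(=O)(=O)Nc2ccc(OC)c(O)c2)c(OC)c1`) has hydroxy in place of fluoro on an aromatic carbon, ortho to a methoxy group and meta to a large group: hydroxy in place of fluoro on an aromatic carbon. Going by the values given here, the only measured step that bears on this change is no change at the digits printed from compound 1 to compound 2 (within the scatter), where fluoro took the place of hydrogen on an aromatic carbon. Among the compounds with values here, that flat step says little about hydroxy, which no measured compound carries, so the data fix no direction. A modest move toward stronger inhibition in this assay is a tentative expectation, and a result within the scatter would be no surprise. The expected step is a 2.5-fold lower number from compound 2 to compound 3 (0.40 log units; beyond the scatter). Compound 3 is estimated at 80 nM, with an expected range of 15 nM to 300 nM.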

Compound 3, half-maximal inhibitory concentration: 30 nM
Compound 3: the middle estimate sits 2.7-fold (0.43 log units) above what was measured, within the range that was stated.
By their numbers in this assay, from the lowest: compound 3; then compounds 1 and 2 (each within the scatter of the next).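

In this assay this position proves able to respond to a change, which the flat step from hydrogen to fluoro did not reveal. Hydroxy in place of fluoro gives a 6.7-fold lower number from compound 2 to compound 3 (0.82 log units; beyond the scatter) and hydroxy in place of hydrogen gives a 6.7-fold lower number from compound 1 to compound 3 (0.82 log units; beyond the scatter) so the two substituents differ here even though fluoro alone left the number where it was. Hydroxy brings a hydrogen-bond donor and a hydrogen-bond acceptor that fluoro is not counted as having, but no measurement shown explains why the number falls.

As far as these compounds go, it remains open whether an amine or a carboxylic acid on this same aromatic carbon would match hydroxy. From the compounds shown here alone, it is equally open whether hydroxy would give a similar step on another carbon of this ring.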